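Compound 3 to compound 4: cyclohexylamino in place of ethoxy

A few compounds are considered here, and "the series" means these few. Any claim that something is new, unique, unknown or untested is made for them only; others in the source may bear on it.

compound 1 `C=CC(=O)Nc1nc(-c2ccc(O)cc2)cs1`: 7100 nM
compound 2 `C=CC(=O)Nc1nc(-c2ccccc2)c(C)s1`: 20100 nM
compound 3 `C=CC(=O)N(CC(=O)OCC)c1nc(-c2ccccc2)cs1`: > 30000 nM

Among the compounds with values here, all values come from a functional assay on HCT-116 cells (Homo sapiens) for antiproliferative activity, read by MTT assay, with a stated time of 72 h (a higher number here means a weaker inhibitor, a lower number a stronger inhibitor), and are the only readings available for this series. Compound 1 at 7100 nM and compound 2 at 20100 nM are the exact readings.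

Compound 3 reads > 30000 nM as a limit of the assay and not as a number. Compound 3 therefore marks the limit of > 30000 nM in this assay, at which 1 of the 3 values shown sits, and gives no exact starting point.

The change to compound 4 `C=CC(=O)N(CC(=O)NC1CCCCC1)c1nc(-c2ccccc2)cs1` puts cyclohexylamino in place of ethoxy on a carbonyl carbon, in detail cyclohexylamino in place of ethoxy on a carbonyl carbon at that one place. Within the data shown here, no measured pair carries this change, so the size of the step has no direct support.

The expected step of an at least 2.0-fold lower number from compound 3 to compound 4 (0.30 log units; that floor lies within the scatter) is small and towards a stronger inhibitor, and it is only an estimate since it starts from a limit. The expectation stays near compound 2 at 20100 nM in the same read-out. A second reading at the limit is also expected to be quite possible for compound 4.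

Compound 4 is estimated at 15000 nM in this assay with an expected range from 5000 nM to 30000 nM in that read-out.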

Compound 4, half-maximal inhibitory concentration: >= 29300 nM
Compound 4: a limit, no number (the forecaster's own chance of this, stated with the estimate: 35%); middle value at least 1.9-fold (0.29 log units) from the limit.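

In this assay compound 4 gives >= 29300 nM as a limit of the assay and not a number. Compound 3 gives > 30000 nM as a limit as well. Within the data shown here, no step from compound 3 to compound 4 can be read from these two limits. The compounds shown leave open whether cyclohexylamino in place of ethoxy on a carbonyl carbon shifts this reading at all.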